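Cytotoxicity notes: amidoxime replaced by methyl on compound 1

The source may report more compounds than this note shows. Statements on the series, on what has been measured and on what is new or still open speak of the compounds shown alone.

Measured so far:
compound 1 `CC1(c2ccc(-c3ccc(/C(N)=N\O)cc3)cc2)CC(S(=O)(=O)c2ccc(F)cc2)=C(c2ccc(/C(N)=N\O)cc2)O1`: 3940 nM
compound 2 `CC1(Cc2ccccc2)CC(S(=O)(=O)c2ccccc2F)=C(c2ccc(/C(N)=N\O)cc2)O1`: 29100 nM

In an ADME assay on J774.A1 cells (Mus musculus) for cytotoxicity, read by MTT assay, with a stated time of 72 h (a lower number here means that less compound is tolerated, a higher number that more compound is tolerated), compound 1 gives 3940 nM, the lowest of the two numbers, so it is the less tolerated of the pair. Compound 2 gives 29100 nM, a higher number, beyond the scatter. Compound 3 `Cc1ccc(-c2ccc(C3(C)CC(S(=O)(=O)c4ccc(F)cc4)=C(c4ccc(/C(N)=N\O)cc4)O3)cc2)cc1` is not yet measured. It differs from compound 1 by one carbon atom in place of a group of 4 heavy atoms (1 carbon, 2 nitrogen, 1 oxygen; no ring), on an aromatic carbon, a methyl entering where the larger group leaves. Among the compounds with values here, no measured pair isolates this change; the step is expected to be modest and towards a higher number, perhaps only just beyond the scatter, as a 2.0-fold higher number from compound 1 to compound 3 (0.31 log units; beyond the scatter). For compound 3 the estimate is 8000 nM, within 2500 nM to 25000 nM.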

Compound 3, half-maximal cytotoxic concentration: 7910 nM
Estimate against measurement, compound 3: 1.0-fold (0.00 log units) above, and the stated range covers the measured number.
By their numbers in this assay, from the lowest: compounds 1 and 3 (each within the scatter of the next); then compound 2.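

In this assay, methyl in place of the group of 4 heavy atoms, on an aromatic carbon para to a large group, gives a 2.0-fold higher number from compound 1 to compound 3 (0.30 log units; within the scatter). This first one-place pair in the series shows that, on the core of compound 1, the hydrogen-bond donors and acceptors counted on that group can leave this position without a step beyond the scatter. Nothing measured here accounts for this result.

Going by these compounds, whether an amine, a carboxylic acid or a longer chain at this position would also stay within the scatter remains open. So does the effect of exchanging the same group where it remains in compound 3.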